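Acetoxymethyl in place of trifluoroethoxymethyl on the furan

The source may report more compounds than this note shows. Statements on the series, on what has been measured and on what is new or still open speak of the compounds shown alone.

Three compounds share one core and differ only in the group on the furan carbon. Compound 1 `CCCOC(=O)c1c(C)coc1-c1ccc2c(CC)cccc2c1OC` carries a propoxycarbonyl group there; in a functional assay on ZR-75-1 cells (Homo sapiens) for cytotoxicity, read by MTT assay, with a stated time of 72 h (on this read-out higher numbers stand for an effect only at larger amounts of compound and lower numbers for an effect already at smaller amounts), compound 1 gives only a limit, > 10 ug/mL. Compound 2 `CCc1cccc2c(OC)c(-c3occ(C)c3COC)ccc12` carries a methoxymethyl group and gives 9.7 ug/mL in this assay. Compound 3 `CCc1cccc2c(OC)c(-c3occ(C)c3COCC(F)(F)F)ccc12` carries a (2,2,2-trifluoroethoxy)methyl group and gives 5.3 ug/mL, the lowest of the two numbers, though the step of a 1.8-fold lower number from compound 2 to compound 3 (0.26 log units; within the scatter) is within the scatter; the steps of an at least 1.0-fold lower number from compound 1 to compound 2 (0.01 log units; that floor lies within the scatter) and an at least 1.8-fold lower number from compound 1 to compound 3 (0.27 log units; that floor lies within the scatter) start from a limit, as noted in the limit of > 10 ug/mL in this assay, at which 1 of the 3 values shown sits.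

Compound 4 `CCc1cccc2c(OC)c(-c3occ(C)c3COC(C)=O)ccc12` is the next compound, not yet measured: acetyl in place of 2,2,2-trifluoroethyl on an oxygen on a saturated carbon. Going by the values given here, of the measured steps, only the step from compound 2 to compound 3 touches the same oxygen, and it was small; no measured step puts an acetyl group in. The account therefore expects no step beyond the scatter, or at most a modest rise, a 1.4-fold higher number from compound 3 to compound 4 (0.15 log units; within the scatter). Compound 4 is estimated to give 7.5 ug/mL in this assay, within the range 3.5 ug/mL to 16 ug/mL.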

Compound 4, concentration for half-maximal effect: 3.5 ug/mL
Compound 4: middle estimate off by 2.1-fold (0.33 log units), on the high side, and the stated range covers the measured number.
By their numbers in this assay, from the lowest: compounds 4, 3 and 2 (each within the scatter of the next, the first and the last beyond it). At a limit, above all of these: compound 1.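

Acetyl in place of methyl on this oxygen gives a 2.8-fold lower number from compound 2 to compound 4 (0.44 log units; beyond the scatter), the first step between two exact numbers in this assay to clear the scatter, so the group on this oxygen can shift the read-out measurably. Acetyl in place of 2,2,2-trifluoroethyl gives a 1.5-fold lower number from compound 3 to compound 4 (0.18 log units; within the scatter), so these two groups cannot be told apart here, and only the comparison of acetyl with methyl separates two groups on this oxygen. Acetoxymethyl in place of propoxycarbonyl on the aromatic carbon gives an at least 2.8-fold lower number from compound 1 to compound 4 (0.45 log units; beyond the scatter), which fixes only a floor and no exact size, since the value of compound 1 is a limit: the limit of > 10 ug/mL in this assay, at which 1 of the 4 values shown sits.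

The compounds shown leave open whether a free hydroxyl, a butanoyl chain or a carbamoyl group on the same oxygen would read like acetyl or like methyl. They also leave open whether the acetyl group itself matters or whether the same reading would follow from a benzoyl group there, and whether the step between acetyl and methyl would hold on other cells.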